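Methyl for Fluoro in the (4-Fluorophenyl)carbonyl Series

The compounds below may be only part of what the source reports. "The series", "measured", "known", "first", "only" and "open" are said of these compounds alone.

Of the compounds shown here, two with the shared core have been measured so far. Compound 1 `CC(Cn1cnc2c1c(=O)n(C)c(=O)n2C)OC(=O)CC(=O)c1ccc(F)cc1` gives 76.8% in a functional assay on MCF7 cells (Homo sapiens) for antiproliferative activity, read by MTT assay, with a stated time of 72 h, tested at 200 uM (a lower number here means a stronger effect, a higher number a weaker effect of the compound at the concentration tested), the highest of the two numbers and therefore the weaker effect at the concentration tested. Compound 2 `CC(Cn1cnc2c1c(=O)n(C)c(=O)n2C)OC(=O)Sc1ccccc1` gives 43.1% in this assay, a number lower than that of compound 1 by more than the usual scatter. These two differ in more than one place, so no single-step comparison is available yet.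

Compound 3 `Cc1ccc(C(=O)CC(=O)OC(C)Cn2cnc3c2c(=O)n(C)c(=O)n3C)cc1` is the next candidate. It differs from compound 1 by methyl in place of fluoro on an aromatic carbon; cut one bond further out, the exchange reads (4-fluorophenyl)carbonyl to (4-methylphenyl)carbonyl. Going by the values given here, no step of this kind has been measured. The step is expected to be small, a number 4.8 percentage points lower from compound 1 to compound 3 (within the scatter), a slight drop at most and likely none beyond the scatter. Compound 3 is accordingly estimated at 72% in this assay, with a range from 55% to 90%.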

Compound 3, a percentage reported as activity, at one concentration (the size of the read-out at that concentration, not a potency): 82.7%
Beside the measured number, compound 3's estimate is 10.7 percentage points below it; measured number inside the range.
By their numbers in this assay, from the lowest: compound 2; then compounds 1 and 3 (each within the scatter of the next).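

Going by these compounds alone, the first step that differs in one place, methyl in place of fluoro on an aromatic carbon para to a large group, reads in this assay as a number 5.9 percentage points higher from compound 1 to compound 3 (within the scatter) and therefore shows no change beyond the scatter. At this position, 4-fluorophenyl and 4-methylphenyl cannot be told apart at the concentration tested, so this exchange is tolerated without a measurable loss or gain in this read-out. Nothing available explains this outcome.

As far as these compounds go, whether an amine or a carboxylic acid on the same aromatic carbon would move the number beyond the scatter remains open. From the compounds shown here alone, it is also open whether the equivalence of fluoro and methyl would hold at other concentrations, where a difference between compound 1 and compound 3 might appear.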